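Shifting the Fluorine in Compound 1

A few compounds are considered here, and "the series" means these few. Any claim that something is new, unique, unknown or untested is made for them only; others in the source may bear on it.

For the measured compounds named here, compound 1 `COc1cc(OC)cc(N2CCN(C(=O)c3onc(C)c3-c3ccccc3F)CC2)c1` is the only compound with a measured number in a functional assay on HL-60 cells (Homo sapiens) for inhibition, read by MTT assay, with a stated time of 72 h (a higher number here means a weaker inhibitor, a lower number a stronger inhibitor), where compound 1 gives 165 nM. Compound 2 `CC(=O)c1ccc(N2CCN(C(=O)c3oc(C)nc3-c3ccccc3)CC2)cc1` is reported as "not active" (no number reported). Compound 3 `Cc1ccc(N2CCN(C(=O)c3oc(C)nc3-c3ccccc3)CC2)cc1` gives > 1000 nM, which is a limit of the assay and not a number. Compound 4 `COc1cc(OC)cc(N2CCN(C(=O)c3onc(C)c3-c3cccc(F)c3)CC2)c1` keeps the core of compound 1 but carries 3-fluorophenyl in place of 2-fluorophenyl on an aromatic carbon. Going by the values given here, no measured pair shows what such a change does, so only a modest step toward weaker inhibition in this assay is expected, perhaps none beyond the scatter. The expected change is a 1.5-fold higher number from compound 1 to compound 4 (0.18 log units; within the scatter). Compound 4 is estimated at 250 nM, with an expected range of 70 nM to 900 nM.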

Compound 4, half-maximal inhibitory concentration: 152 nM
Beside the measured number, compound 4's estimate is 1.6-fold (0.22 log units) above it; low and high end bracket the measured number.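

For the compounds shown here, the step of a 1.1-fold lower number from compound 1 to compound 4 (0.04 log units; within the scatter) in this assay is the first reading of any change at this position. It shows that, on the core of compound 1, 3-fluorophenyl serves in place of 2-fluorophenyl with no difference that can be told from the scatter. Nothing at hand accounts for this result.

As far as these compounds go, whether the fluorine matters at all remains open, as does what a plain phenyl or a pyridyl group would do at this position on the shared core.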